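Adding a methyl to the ring nitrogen of compound 1

The source may hold more compounds than are shown below. What is called first, only, known or untested is meant among the compounds shown, and "the series" means these compounds.

- compound 1 `O=[N+]([O-])c1ccc(-c2nc3cc(C(F)(F)F)ccc3[nH]2)cc1`: 18000 nM
- compound 2 `O=[N+]([O-])c1ccc(-c2nc3cc(C(F)(F)F)ccc3[nH]2)c([N+](=O)[O-])c1`: 8000 nM
- compound 3 `Fc1ccc(-c2nc3cc(C(F)(F)F)ccc3[nH]2)cc1`: 25000 nM

In an ADME assay on BHK cells (Mesocricetus auratus) for cytotoxicity, read by MTT assay, with a stated time of 96 h (a higher number here means that more compound is tolerated, a lower number that less compound is tolerated), compound 1 gives 18000 nM, the middle of the three numbers. Compound 4 `Cn1c(-c2ccc([N+](=O)[O-])cc2)nc2cc(C(F)(F)F)ccc21` differs from it in one place: methyl in place of hydrogen on an aromatic nitrogen. Among the measured compounds shown here, no measured step changes that nitrogen. The two available steps, both on aromatic carbons, are only a rough guide to size: a 1.4-fold higher number from compound 1 to compound 3 (0.14 log units; within the scatter) and a 2.3-fold lower number from compound 1 to compound 2 (0.35 log units; beyond the scatter). Since neither is large, no step beyond the scatter is expected, though this remains uncertain. Compound 4 is estimated at 20000 nM, with an expected range of 8000 nM to 50000 nM. The estimated change is a 1.1-fold higher number from compound 1 to compound 4 (0.05 log units; within the scatter).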

Compound 4, half-maximal cytotoxic concentration: > 100000 nM
Compound 4 was reported as a limit; the forecaster's own chance of this, stated with the estimate: 15%; middle value at least 5.0-fold (0.69 log units) away from the limit.
By their numbers in this assay, from the lowest: compound 2; then compounds 1 and 3 (each within the scatter of the next). At a limit, above all of these: compound 4.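

On this aromatic nitrogen, methyl in place of hydrogen gives an at least 5.5-fold higher number from compound 1 to compound 4 (0.74 log units; beyond the scatter) in this assay, a larger shift than either step on an aromatic carbon had shown. The earlier compounds shown here all keep this hydrogen, so they gave no sign that this position could matter so much. The value of compound 4 is a limit and not a number: the limit of > 100000 nM in this assay, at which 1 of the 4 values shown sits.

Going by these compounds, it remains open whether an ethyl group or a longer chain on this nitrogen would act as methyl does. On these data alone, it is also open whether methyl would give a similar step on the cores of compound 2 and compound 3.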